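Adding a Chloro Group to Compound 2

The compounds below may be only part of what the source reports. "The series", "measured", "known", "first", "only" and "open" are said of these compounds alone.

In a functional assay on HeLa cells (Homo sapiens) for cytotoxicity, read by MTT assay, with a stated time of 72 h (a higher number here means a weaker inhibitor, a lower number a stronger inhibitor), compound 1 `Cn1ccc2c(Oc3ccc(NC(=O)c4cc5cccnc5n(-c5ccccc5)c4=O)cc3)ncnc21` gives 59800 nM as its number and compound 2 `Cn1ccc2c(Oc3ccc(NC(=O)c4cc5cccnc5n(-c5ccccc5)c4=O)cc3F)ncnc21` gives 51800 nM as its number. Within the data shown here, compound 2 therefore stands level with compound 1, the only other compound measured so far.

Compound 3 `Cn1ccc2c(Oc3ccc(NC(=O)c4cc5cccnc5n(-c5ccc(Cl)cc5)c4=O)cc3F)ncnc21` is compound 2 with one change, from phenyl to 4-chlorophenyl: chloro in place of hydrogen on an aromatic carbon, para to a large group. That change counts as chloro in place of hydrogen on an aromatic carbon in full.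

Among the measured compounds shown here, only one measured step offers any guide, namely a 1.2-fold lower number from compound 1 to compound 2 (0.06 log units; within the scatter) for the two tested compounds. That step also puts a halogen in place of hydrogen, but it is fluoro rather than chloro and sits elsewhere in the molecule, so it is only a loose comparison. For the measured compounds named here, no measurement yet shows what chloro does.

In this assay no step beyond the scatter is therefore expected, and the estimate is a 1.3-fold lower number from compound 2 to compound 3 (0.11 log units; within the scatter) in size. For compound 3 the estimated value is 40000 nM with an expected range from 14000 nM to 90000 nM on this thin evidence.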

Compound 3, half-maximal inhibitory concentration: 43900 nM
Compound 3: middle estimate off by 1.1-fold (0.04 log units), on the low side; low and high end bracket the measured number.
By their numbers in this assay, from the lowest: compounds 3, 2 and 1 (each within the scatter of the next).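

In this assay, the phenyl group now has its first measured substitution: going from phenyl to 4-chlorophenyl gives a 1.2-fold lower number from compound 2 to compound 3 (0.07 log units; within the scatter), so compound 3 stands level with compound 2. Together with the earlier fluoro step elsewhere in the molecule, a 1.2-fold lower number from compound 1 to compound 2 (0.06 log units; within the scatter), this means that each of the two halogen changes shown stays within the scatter, so neither separates a compound from its direct partner. This says only that chloro at this one place leaves the cell result level in this pair, and no separate measurement is on hand to explain the result.

The compounds shown leave open whether a different group at the same place, such as an amine, a carboxylic acid or a longer chain, would produce a step beyond the scatter. They also leave open whether the same phenyl to 4-chlorophenyl change would stay within the scatter on compound 1, which lacks the fluoro group carried by compound 2.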